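The compounds below may be only part of what the source reports. "The series", "measured", "known", "first", "only" and "open" are said of these compounds alone.

Compound 3 `COc1cc2c(Oc3ccc(NC(=O)c4nn(-c5cccc(F)c5)c(=O)cc4C)cc3F)ccnc2cc1OCCCN1CCC(C)CC1` gives 300 nM in a functional assay on HT-29 cells (Homo sapiens) for inhibition, read by MTT assay, with a stated time of 72 h (on this read-out higher numbers stand for weaker inhibition and lower numbers for stronger inhibition), the highest of the three numbers in hand, though within the scatter of both neighbours. Compound 2 `COc1cc2c(Oc3ccc(NC(=O)c4nn(-c5cccc(F)c5)c(=O)cc4C)cc3F)ccnc2cc1OCCCN1CCCC1` gives 250 nM and compound 1 `COc1cc2c(Oc3ccc(NC(=O)c4nn(-c5ccccc5C(F)(F)F)c(=O)cc4C)cc3F)ccnc2cc1OCCCN1CCN(C)CC1` gives 170 nM. The next member, compound 4 `COc1cc2c(Oc3ccc(NC(=O)c4nn(-c5cccc(F)c5)c(=O)cc4C)cc3F)ccnc2cc1OCCCN1CCN(C)CC1`, carries 4-methylpiperazin-1-yl in place of 4-methylpiperidin-1-yl on a saturated chain carbon, three bonds along the chain from an oxygen on an aromatic ring. Within the data shown here, the only measured step at this position is a 1.2-fold higher number from compound 2 to compound 3 (0.08 log units; within the scatter), an amine swap that left the number essentially unchanged. Among the measured compounds shown here, compound 1 already holds the 4-methylpiperazin-1-yl group and shows a value in the same band, though its other ring differs, so no step to it is drawn. On this basis the expected step of a 1.4-fold lower number from compound 3 to compound 4 (0.13 log units; within the scatter) is none beyond the scatter. Compound 4 is estimated at 220 nM, with a range of 110 nM to 450 nM.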

Compound 4, half-maximal inhibitory concentration: 250 nM
Compound 4: middle estimate off by 1.1-fold (0.06 log units), on the low side; the range from low to high includes it.
By their numbers in this assay, from the lowest: compounds 1, 2, 4 and 3 (each within the scatter of the next).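

In this assay, 4-methylpiperazin-1-yl in place of 4-methylpiperidin-1-yl gives (a 1.2-fold lower number from compound 3 to compound 4 (0.08 log units; within the scatter)), and in place of pyrrolidin-1-yl gives (no change at the digits printed from compound 2 to compound 4 (within the scatter)), so these three amines are not separated on this read-out. On an aromatic nitrogen, 3-fluorophenyl in place of 2-(trifluoromethyl)phenyl gives (a 1.5-fold higher number from compound 1 to compound 4 (0.17 log units; within the scatter)), so that pair is not separated either. No evidence is available that bears on these results.

Open, as far as these compounds go, is whether morpholin-4-yl or a carboxylic acid at the same place on the chain would give a step beyond the scatter. From the compounds shown here alone, a longer chain carrying 4-methylpiperazin-1-yl also remains open.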